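Shortening a side chain: from compound 2 to compound 3

The source may report more compounds than this note shows. Statements on the series, on what has been measured and on what is new or still open speak of the compounds shown alone.

Measured so far:
compound 1, `CCCCC1(CCCC)C[C@@H](CNCCCn2ccnc2)[C@@](CCCC)(OC)OO1`: 32500 nM
compound 2, `CCCC[C@]1(OC)OOC(c2ccccc2)(c2ccccc2)C[C@H]1CNCCCn1ccnc1`: 9500 nM

In an ADME assay on Vero cells (Chlorocebus sabaeus) for cytotoxicity, read by resazurin assay, with a stated time of 72 h (a higher number here means that more compound is tolerated, a lower number that less compound is tolerated), compound 2 gives the lower of the two numbers shown, and compound 1 gives the higher; that gap lies beyond the usual scatter. Compound 3, `CO[C@@]1(C)OOC(c2ccccc2)(c2ccccc2)C[C@H]1CNCCCn1ccnc1`, has not been measured. It differs from compound 2 in one place: hydrogen in place of propyl on a saturated chain carbon bound to a saturated ring carbon. Within the data shown here, no measured pair shows what this change does here, so the expectation rests on compound 2 alone. A small step toward a higher number is expected, a 1.5-fold higher number from compound 2 to compound 3 (0.17 log units; within the scatter), not clearly beyond the scatter. Compound 3 is estimated at 14000 nM, within 6000 nM to 35000 nM.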

Compound 3, half-maximal cytotoxic concentration: 50000 nM
Estimate against measurement, compound 3: 3.6-fold (0.55 log units) below; the whole stated range lies below it.
By their numbers in this assay, from the lowest: compound 2; then compounds 1 and 3 (each within the scatter of the next).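

In this assay, among these compounds, hydrogen in place of propyl on a saturated chain carbon bound to a saturated ring carbon gives a 5.3-fold higher number from compound 2 to compound 3 (0.72 log units; beyond the scatter) and so offers the first single-change reading at this position. It shows that this position matters in this assay, with the change, also read as butyl to methyl, moving the number beyond the scatter. No measurement shown accounts for the step. From the compounds shown here alone, whether an intermediate ethyl or a longer hexyl chain here would give a graded response remains open. So does whether the same change would act alike on the core of compound 1.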